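This account rests on a few compounds, and the source may have more. Where it says the series, first, only, none or still open, it means among the compounds named here.

Working notes on the series in a functional assay on HCT-116 cells (Homo sapiens) for inhibition, read by MTT assay, with a stated time of 48 h; a lower number here means a stronger inhibitor, a higher number a weaker inhibitor.

Compound 1 `C/C=C/C(=O)N(Cc1ccc(OC)c([N+](=O)[O-])c1)c1cc(OC)c(OC)c(OC)c1` gives 670 nM. Compound 2 `COc1ccc(CNc2cc(OC)c(OC)c(OC)c2)cc1[N+](=O)[O-]` gives 18200 nM; the hydrogen in place of the (prop-1-en-1-yl)carbonyl on the ring nitrogen brings a 27-fold higher number from compound 1 to compound 2 (1.43 log units; beyond the scatter), the largest movement in the set. Compound 3 `C/C=C/C(=O)N(Cc1ccc(OC)c(N)c1)c1cc(OC)c(OC)c(OC)c1` gives 300 nM, the lowest of the three numbers; compound 1 is nearest and compound 2 furthest. The amino in place of nitro on the aromatic carbon gives a 2.2-fold lower number from compound 1 to compound 3 (0.35 log units; beyond the scatter), a modest step.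

Compound 4 `C/C=C/C(=O)N(Cc1ccc(OC)c(C)c1)c1cc(OC)c(OC)c(OC)c1` differs from compound 3 by methyl in place of amino on an aromatic carbon. Among the measured compounds shown here, the only measured step at this aromatic carbon is a 2.2-fold lower number from compound 1 to compound 3 (0.35 log units; beyond the scatter), which shows that changing the group at this place, with the (prop-1-en-1-yl)carbonyl kept on the nitrogen as it is in compound 4, moves the number only modestly. For the measured compounds named here, no measured compound carries a methyl at this carbon, so the direction is not fixed by the data; the amino that leaves carries a hydrogen-bond donor and a hydrogen-bond acceptor that the methyl lacks, and compound 1, with nitro at this place, sits somewhat higher than compound 3. A small step in this assay, probably toward a somewhat higher number, is expected: a 1.7-fold higher number from compound 3 to compound 4 (0.22 log units; within the scatter). Compound 4 is estimated at 500 nM, with a range from 200 nM to 1300 nM.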

Compound 4, half-maximal inhibitory concentration: 23500 nM
The estimate for compound 4 lay 47-fold (1.67 log units) below the measured number, and the stated range ends below it.
By their numbers in this assay, from the lowest: compound 3; then compound 1; then compounds 2 and 4 (each within the scatter of the next).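

In this assay, among the compounds shown here, this aromatic carbon proves far less forgiving than the earlier pair suggested: a 78-fold higher number from compound 3 to compound 4 (1.89 log units; beyond the scatter) and a 35-fold higher number from compound 1 to compound 4 (1.54 log units; beyond the scatter) are both large, whereas the only step seen before at this place was modest. Among the three groups now compared here, amino and nitro both place a nitrogen on this carbon and both give low numbers, while methyl places a carbon here and gives a much higher number, so the group on this carbon can decide most of the reading with the (prop-1-en-1-yl)carbonyl kept on the nitrogen. No measurement at hand bears on what lies behind this large change, and the difference in hydrogen-bond donors and acceptors between amino and methyl remains only a count.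

The compounds shown leave open whether a hydroxyl, a fluorine or a methylamino group at this carbon would read with amino and nitro or with methyl. They also leave open how strongly this carbon matters once the nitrogen carries hydrogen, since compound 2, with nitro, is the only such case.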